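Furanylmethyl in Place of Benzyl on the Amine

This account rests on a few compounds, and the source may have more. Where it says the series, first, only, none or still open, it means among the compounds named here.

Going by the values given here, compound 2 `CCOC(=O)c1cn(Cc2ccccc2F)c2c(F)c(-c3ccc(OCC(C)C)cc3)c(CN(C)Cc3ccccc3)n2c1=O` gives 42 nM in an assay on isolated protein for binding affinity to Gonadotropin-releasing hormone receptor (Homo sapiens) (on this read-out higher numbers stand for weaker inhibition and lower numbers for stronger inhibition), the lowest of the two numbers known. Compound 1 `CCOC(=O)c1cn(Cc2ccccc2F)c2c(F)c(-c3cccc(OC)c3)c(CN(C)Cc3ccccc3)n2c1=O` gives 2600 nM, and the step of a 62-fold lower number from compound 1 to compound 2 (1.79 log units; beyond the scatter) concerns a different part of the molecule. Compound 3 `CCOC(=O)c1cn(Cc2ccccc2F)c2c(F)c(-c3ccc(OCC(C)C)cc3)c(CN(C)Cc3ccco3)n2c1=O` differs from compound 2 by furan-2-yl in place of phenyl on a saturated chain carbon bound to an amine nitrogen. Among the compounds with values here, no measured step touches this position, so nothing here tells how the substitution will read. The expected step is therefore about a 1.3-fold higher number from compound 2 to compound 3 (0.12 log units; within the scatter), not beyond the scatter. Compound 3 is expected near 55 nM, with a range from 15 nM to 200 nM.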

Compound 3, inhibition constant: 92 nM
Compound 3: the middle estimate sits 1.7-fold (0.22 log units) below what was measured, and the stated range covers the measured number.
By their numbers in this assay, from the lowest: compound 2; then compound 3; then compound 1.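

In this assay, going by these compounds alone, this is the first reading at this position, and furan-2-yl in place of phenyl on a saturated chain carbon bound to an amine nitrogen gives a 2.2-fold higher number from compound 2 to compound 3 (0.34 log units; beyond the scatter) as a modest step. The phenyl can therefore be exchanged for a five-membered aromatic ring with one hetero atom at a modest cost in this series. Nothing available explains the step. The compounds shown leave open whether the ring size or the ring oxygen accounts for it, as both change together. Going by these compounds, how thiophen-2-yl or pyridin-2-yl would read at this place also stays open.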